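Restoring the 2-hydroxyphenyl on the hydrazone carbon

This account rests on a few compounds, and the source may have more. Where it says the series, first, only, none or still open, it means among the compounds named here.

Measured so far:
compound 1, `Cc1c(C(=O)N/N=C\c2ccccc2O)oc2cccc(O)c12`: 8350 nM
compound 2, `Cc1c(C(=O)N/N=C\c2cccnc2)oc2cccc(O)c12`: >= 40000 nM

In a functional assay on PC-3 cells (Homo sapiens) for inhibition (on this read-out lower numbers stand for stronger inhibition and higher numbers for weaker inhibition), compound 1 gives 8350 nM. In the same assay compound 2 gives >= 40000 nM, which is a limit of the assay and not a number. Compound 2 therefore stands at the limit of >= 40000 nM in this assay, at which 1 of the 2 values shown sits, the weaker end of the two values shown.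

Compound 3, `Cc1c(C(=O)N/N=C\c2cccc(Br)c2O)oc2cccc(O)c12`, is not yet measured. It differs from compound 2 by 3-bromo-2-hydroxyphenyl in place of pyridin-3-yl on a carbon with a double bond to nitrogen.

Going by the values given here, the one measured step that bears on this change is an at least 4.7-fold higher number from compound 1 to compound 2 (0.68 log units; beyond the scatter), since it concerns the same carbon with a double bond to nitrogen and shows that pyridin-3-yl in place of 2-hydroxyphenyl weakens inhibition. Compound 3 reverses that exchange and adds a bromine within the 3-bromo-2-hydroxyphenyl group. The return of the hydroxyphenyl is expected to bring the number back toward compound 1, a step of about an at least 5.0-fold lower number from compound 2 to compound 3 (0.69 log units; beyond the scatter) toward stronger inhibition. For compound 3 the expected value is 8000 nM, within 3000 nM to 25000 nM.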

Compound 3, half-maximal inhibitory concentration: 16600 nM
Beside the measured number, compound 3's estimate is 2.1-fold (0.32 log units) below it; measured number inside the range.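

Compound 2 is a limit of the assay and not a number in this assay: the limit of >= 40000 nM in this assay, at which 1 of the 3 values shown sits. Placing 3-bromo-2-hydroxyphenyl instead of pyridin-3-yl on the carbon with a double bond to nitrogen gives an at least 2.4-fold lower number from compound 2 to compound 3 (0.38 log units; beyond the scatter), so a second hydroxyphenyl-bearing compound, besides compound 1, returns a value inside the range of the assay, and the true size of this step stays open on one side. Bromo in place of hydrogen on an aromatic carbon gives a 2.0-fold higher number from compound 1 to compound 3 (0.30 log units; within the scatter), which lies within the scatter, so in this pair the added bromine brings no change that can be told apart from repeat measurement, a point the earlier pair could not address.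

The compounds shown do not separate the contribution of the hydroxyl from that of the carbon-only ring, and a plain phenyl or an aminophenyl at this position would be needed to pull the two apart. They also leave open whether a different halogen, such as chlorine, or a methoxy group in place of the bromine would behave as the bromine does here.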